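The compounds below may be only part of what the source reports. "The series", "measured", "known", "first", "only" and "open" are said of these compounds alone.

Measured in a functional assay on U-87MG ATCC cells for cytotoxicity against U-87 MG (Homo sapiens), read by MTT assay, with a stated time of 72 h; a higher number here means a weaker inhibitor, a lower number a stronger inhibitor:
- compound 1 `COc1ncc(-c2ccc3nc(NC(=O)N4CCCC4)nn3c2)cc1NS(=O)(=O)c1ccc(F)cc1`: 1690 nM
- compound 2 `COc1ncc(-c2ccc3nc(NC(=O)N(C)C)nn3c2)cc1NS(=O)(=O)c1ccc(F)cc1`: 1780 nM
- compound 3 `COc1ncc(-c2ccc3nc(NC(=O)NCCN4CCCC4)nn3c2)cc1NS(=O)(=O)c1ccc(F)cc1`: 1120 nM

Compound 2, at 1780 nM, stands within the scatter of both other compounds. Compound 4 `COc1ncc(-c2ccc3nc(NC(=O)NC4CC4)nn3c2)cc1NS(=O)(=O)c1ccc(F)cc1` has not yet been measured. It carries cyclopropylamino in place of dimethylamino on a carbonyl carbon. Three measured steps change the group at this same place: a 1.1-fold higher number from compound 1 to compound 2 (0.02 log units; within the scatter), a 1.5-fold lower number from compound 1 to compound 3 (0.18 log units; within the scatter) and a 1.6-fold lower number from compound 2 to compound 3 (0.20 log units; within the scatter). All three lie within the scatter, but none of them tests cyclopropylamino. No step beyond the scatter is therefore expected in this assay. The estimated change is a 1.2-fold lower number from compound 2 to compound 4 (0.07 log units; within the scatter). For compound 4 the expected value is 1500 nM, with an estimated range of 600 nM to 3800 nM.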

Compound 4, half-maximal inhibitory concentration: 540 nM
The estimate for compound 4 lay 2.8-fold (0.44 log units) above the measured number; measured number outside the range, below it.
By their numbers in this assay, from the lowest: compound 4; then compounds 3, 1 and 2 (each within the scatter of the next).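

In this assay cyclopropylamino on the carbonyl carbon separates itself beyond the scatter from dimethylamino (a 3.3-fold lower number from compound 2 to compound 4 (0.52 log units; beyond the scatter)), pyrrolidin-1-yl (a 3.1-fold lower number from compound 1 to compound 4 (0.50 log units; beyond the scatter)) and (2-(pyrrolidin-1-yl)ethyl)amino (a 2.1-fold lower number from compound 3 to compound 4 (0.32 log units; beyond the scatter)). Those three groups had stayed within the scatter of one another, so this place does respond to the group it carries, and compound 4 stands lowest of the four. No evidence is at hand to explain this step.

From the compounds shown here alone, whether methylamino, isopropylamino or cyclobutylamino would reach as low a number stays open.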